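This account rests on a few compounds, and the source may have more. Where it says the series, first, only, none or still open, it means among the compounds named here.

For the measured compounds named here, in a functional assay on OVCAR-5 cells (Homo sapiens) for inhibition, read by CCK-8 assay, with a stated time of 72 h, tested at 1 uM (a higher number here means more inhibition of growth at the concentration tested, a lower number less inhibition of growth), compound 1 `CN(C)C(=O)c1cc2cnc(Nc3ccc(NC(=O)C4(C(=O)Nc5cccc(O)c5)CC4)cc3)nc2n1C1CCCC1` gives 58.5%, the higher of the two numbers available so far. Compound 2 `CN(C)C(=O)c1cc2cnc(Nc3ccc(NC(=O)C4(C(=O)Nc5ccc(F)cc5)CC4)cc3F)nc2n1C1CCCC1` gives -0.9%, a gap beyond the scatter. Compound 3 `CN(C)C(=O)c1cc2cnc(Nc3ccc(NC(=O)C4(C(=O)Nc5ccccc5)CC4)cc3)nc2n1C1CCCC1` has not yet been measured. It departs from compound 1 by a single change, hydrogen in place of hydroxy on an aromatic carbon. Going by the values given here, no measured pair isolates this change, so its direction remains uncertain. A moderate loss of growth inhibition is expected, an estimated step of a number 16.5 percentage points lower from compound 1 to compound 3 (beyond the scatter). Compound 3 is estimated at 42%, with an expected range of 15% to 65%.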

Compound 3, percent growth inhibition at one concentration: 52.1%
For compound 3 the middle estimate is 10.1 percentage points below the measured one; the measured number falls inside the stated range.
By their numbers in this assay, from the lowest: compound 2; then compounds 3 and 1 (each within the scatter of the next).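

In this assay, taking away the hydroxy on the aromatic ring gives a step of a number 6.4 percentage points lower from compound 1 to compound 3 (within the scatter), so the change from 3-hydroxyphenyl to phenyl leaves growth inhibition at this concentration unresolved from the scatter. In this one pair, then, the hydroxy at this place is not needed for the inhibition seen. No measurement here offers an explanation for this result. On these data alone, whether an amine, a methoxy group or a carboxylic acid at this place would keep that inhibition remains open. Compound 2 differs from compound 3 in more than one place, so it cannot settle this question.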